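This account rests on a few compounds, and the source may have more. Where it says the series, first, only, none or still open, it means among the compounds named here.

Compound 1 `N#CC1=C(N)N(c2ccc(S(N)(=O)=O)cc2)C2=C(C(=O)CCC2)C1c1ccc(O)cc1` carries a 4-hydroxyphenyl group on the shared core. In a functional assay on Ehrlich cells (Mus musculus) for antiproliferative activity, read by trypan blue exclusion, with a stated time of 2 h, tested at 25 ug/mL (a higher number here means a stronger effect of the compound at the concentration tested, a lower number a weaker effect), compound 1 gives 95%. Compound 2 `COc1ccc(C2C(C#N)=C(N)N(c3ccc(S(N)(=O)=O)cc3)C3=C2C(=O)CCC3)cc1` differs from it by methyl in place of hydrogen on an oxygen on an aromatic ring, and in this assay compound 2 gives 50%. The step reads a number 45 percentage points lower from compound 1 to compound 2 (beyond the scatter). Compound 3 `N#CC1=C(N)N(c2ccc(S(N)(=O)=O)cc2)C2=C(C(=O)CCC2)C1c1c(O)ccc2ccccc12` differs from compound 1 by 2-hydroxynaphthalen-1-yl in place of 4-hydroxyphenyl on a saturated ring carbon, and in this assay compound 3 gives 0%, the lowest of the three. The steps read a number 95 percentage points lower from compound 1 to compound 3 (beyond the scatter) and a number 50 percentage points lower from compound 2 to compound 3 (beyond the scatter). Compound 4 `COc1ccc2ccccc2c1C1C(C#N)=C(N)N(c2ccc(S(N)(=O)=O)cc2)C2=C1C(=O)CCC2` has not yet been measured; it differs from compound 3 by methyl in place of hydrogen on an oxygen on an aromatic ring, the same change as from compound 1 to compound 2, made here on the core of compound 3. That earlier step went downward, not upward. Since compound 3 already gives 0%, there is little room left for a further fall, and nothing in the earlier pair points to a rise. The step is therefore expected to be small, a number 2 percentage points higher from compound 3 to compound 4 (within the scatter). For compound 4 the estimate is 2%, within 0% to 15%.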

Compound 4, a percentage reported as activity, at one concentration (the size of the read-out at that concentration, not a potency): 62%
Beside the measured number, compound 4's estimate is 60 percentage points below it; measured number above the stated range.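

In this assay, the methyl on the oxygen gives a number 62 percentage points higher from compound 3 to compound 4 (beyond the scatter), so this change does not carry from one core to the other with a fixed size or even a fixed direction: the same change on two cores in this assay, a number 45 percentage points lower (beyond the scatter) from compound 1 to compound 2 and a number 62 percentage points higher (beyond the scatter) from compound 3 to compound 4, 107 percentage points apart, beyond the scatter of two such steps. With a methoxy group on both aryl groups the gap is modest, a number 12 percentage points higher from compound 2 to compound 4 (beyond the scatter), while the highest reading stays with the free hydroxy of the 4-hydroxyphenyl group, a number 33 percentage points lower from compound 1 to compound 4 (beyond the scatter). Going by these compounds alone, these are only two matched pairs, each read at one concentration, so they show that the outcome of the change depends on the group that carries it, but they do not show why, and they give no measure of potency.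

The compounds shown leave open whether an ethyl group on that oxygen, or an amine in place of the hydroxy, would follow the 4-hydroxyphenyl pair or the 2-hydroxynaphthalen-1-yl pair. They also leave open whether the same reversal would appear on any other aryl group.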